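The compounds below may be only part of what the source reports. "The series", "measured", "known", "first", "only" and "open" are said of these compounds alone.

Within a functional assay (brain) for displacement of a labelled ligand, with Rattus norvegicus as the target (a higher number here means a weaker inhibitor, a lower number a stronger inhibitor), three compounds have a number so far. Compound 1 `c1ccc([C@H]2OC[C@H]([C@@H]3CCCCN3)O2)cc1` gives 25000 nM. Compound 2 `CC(C)[C@]1(c2ccccc2)OC[C@H]([C@@H]2CCCCN2)O1` gives 45 nM. Compound 3 `CC[C@]1(c2cccc(O)c2)OC[C@H]([C@@H]2CCCCN2)O1` gives 489 nM, the second highest of the three numbers, with compound 2 standing nearest to it and compound 1 standing furthest from it, each of those two pairs separated by more than the usual scatter. Among the compounds with values here, no single-change step between any two of these measured compounds is available.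

Compound 4 `CC[C@]1(c2cccc(N=C=S)c2)OC[C@H]([C@@H]2CCCCN2)O1` has not yet been measured. It differs from compound 3 in one place: a group of 3 heavy atoms (1 carbon, 1 nitrogen, 1 sulfur; no ring) in place of one oxygen atom, on an aromatic carbon. The group enters on an aromatic carbon of a six-membered aromatic ring of carbon only, meta to a large group.

Within the data shown here, with no comparable step among the measured compounds, the size of the step in this assay can only be estimated loosely. Compound 4 is expected to give roughly 1000 nM in this assay, a step of a 2.0-fold higher number from compound 3 to compound 4 (0.31 log units; beyond the scatter) that is estimated to be a modest weakening, near the edge of the scatter, with an expected range from 250 nM to 4000 nM.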

Compound 4, inhibition constant: 590 nM
Compound 4: middle estimate off by 1.7-fold (0.23 log units), on the high side; the range from low to high includes it.
By their numbers in this assay, from the lowest: compound 2; then compounds 3 and 4 (each within the scatter of the next); then compound 1.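

In this assay, exchanging the hydroxy group for an isothiocyanate group on the aromatic carbon gives a 1.2-fold higher number from compound 3 to compound 4 (0.08 log units; within the scatter) and so leaves the number within the scatter. This position therefore takes a group of 3 heavy atoms in place of one oxygen atom without a measurable change. The entering group has 0 hydrogen-bond donors where the hydroxy group has 1, so in this pair the number does not depend on keeping that donor.

From the compounds shown here alone, whether an amine, a carboxylic acid or a methoxy group on this same aromatic carbon would also leave the number in place remains open. No measurement given here explains why the hydroxy and isothiocyanate compounds read alike.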